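Sulfonamide nitrogen substituents: from compound 3 to compound 4

The source may hold more compounds than are shown below. What is called first, only, known or untested is meant among the compounds shown, and "the series" means these compounds.

compound 1 `O=C(/C=C/c1cccnc1)NCCCCCCc1cccc(S(=O)(=O)Nc2ccccc2)c1`: 2.82 nM
compound 2 `Cc1cccc(NS(=O)(=O)c2cccc(CCCCCCNC(=O)/C=C/c3cccnc3)c2)c1`: 13.2 nM
compound 3 `Cc1ccc(C)c(NS(=O)(=O)c2cccc(CCCCCCNC(=O)/C=C/c3cccnc3)c2)c1`: 2.58 nM

All three values come from a functional assay on Huh-7 cells (Homo sapiens) for inhibition, read by CCK-8 assay, with a stated time of 72 h; a lower number here means a stronger inhibitor, a higher number a weaker inhibitor. Compound 3 sits at the low end of the three numbers, level with its nearest neighbour: a 1.1-fold lower number from compound 1 to compound 3 (0.04 log units; within the scatter) stays within the scatter. Only compound 2 stands apart, with a 5.1-fold lower number from compound 2 to compound 3 (0.71 log units; beyond the scatter) lying beyond the scatter.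

The next compound is compound 4 `CC(C)(C)c1ccc(NS(=O)(=O)c2cccc(CCCCCCNC(=O)/C=C/c3cccnc3)c2)cc1`, which carries 4-(tert-butyl)phenyl in place of 2,5-dimethylphenyl on a sulfonamide nitrogen.

Among the compounds with values here, two measured steps bear on this change, both modest and both methyl in place of hydrogen on an aromatic carbon. One runs upward, a 4.7-fold higher number from compound 1 to compound 2 (0.67 log units; beyond the scatter), and the other runs downward, a 5.1-fold lower number from compound 2 to compound 3 (0.71 log units; beyond the scatter). Changes to this substituent have therefore moved the number in both directions, and no measured compound carries the 4-(tert-butyl)phenyl group. The direction is thus poorly fixed. A modest rise in this assay is still expected rather than a fall, given that compound 3 already sits at the low end and compound 2 at 13.2 nM shows what one substituent change can cost.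

The expected step is a 2.3-fold higher number from compound 3 to compound 4 (0.37 log units; beyond the scatter).

For compound 4 the estimated value is 6 nM, with an expected range of 1.5 nM to 25 nM.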

Compound 4, half-maximal inhibitory concentration: 163 nM
Compound 4: middle estimate off by 27-fold (1.43 log units), on the low side; measured number outside the range, above it.
By their numbers in this assay, from the lowest: compounds 3 and 1 (each within the scatter of the next); then compound 2; then compound 4.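

In this assay the substituent on the sulfonamide nitrogen proves able to move the number much further than the earlier modest methyl steps suggested: 4-(tert-butyl)phenyl in place of 2,5-dimethylphenyl gives a 63-fold higher number from compound 3 to compound 4 (1.80 log units; beyond the scatter) in this series. The loss does not depend on which earlier compound serves as the reference, since the comparison with the phenyl group gives a 58-fold higher number from compound 1 to compound 4 (1.76 log units; beyond the scatter) and 4-(tert-butyl)phenyl in place of 3-methylphenyl gives a 12-fold higher number from compound 2 to compound 4 (1.09 log units; beyond the scatter) as well, which leaves compound 4 as the weakest of the four. No supporting measurement bears on why this group costs so much.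

Still open, as far as these compounds go, is whether the loss belongs to the tert-butyl group itself or to any single group at that place on the phenyl ring, and 4-methylphenyl or 4-chlorophenyl on the sulfonamide nitrogen would help separate the two. The shown compounds also leave unsettled why one methyl-bearing ring, in compound 2, stands apart from the two-methyl ring of compound 3, so a 3,5-dimethylphenyl or 2-methylphenyl group would be the next informative comparison.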